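The source may hold more compounds than are shown below. What is called first, only, known or untested is meant among the compounds shown, and "the series" means these compounds.

Measured so far in a functional assay on SK-BR-3 cells (Homo sapiens) for cytotoxicity, read by MTT assay, with a stated time of 72 h; a lower number here means that less compound is needed, a higher number that more compound is needed for the effect:

- compound 1, `O=c1cc(Nc2ccccc2)cc(-c2ccccc2)o1`: 0.13 uM
- compound 2, `COc1ccc(Nc2cc(/C=C/c3ccccc3)oc(=O)c2)cc1`: 0.083 uM
- compound 3, `Cc1ccc(Nc2cc(-c3ccccc3)oc(=O)c2)cc1`: 0.09 uM

Compound 3 sits second highest of the three numbers in this assay, though all three lie close together: its nearest neighbour is compound 2, with a number only slightly lower, and its furthest is compound 1, with a number only slightly higher, both gaps within the scatter. Among the compounds with values here, the one single-point step available is a 1.4-fold lower number from compound 1 to compound 3 (0.16 log units; within the scatter), which shows that adding a methyl at this ring position did not move the number beyond the scatter.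

Compound 4, `COc1ccc(Nc2cc(-c3ccccc3)oc(=O)c2)cc1`, has not yet been run in this assay. Its change from compound 3 is methoxy in place of methyl on an aromatic carbon. Compound 2 also carries a methoxy on the aniline ring, but it differs from compound 4 elsewhere as well, so its value can only be set beside the others, not read as a step for this change.

The step on record for a small substituent at this position is within the scatter, and the three numbers span a narrow range, so the expectation for compound 4 is a step of about a 1.1-fold lower number from compound 3 to compound 4 (0.02 log units; within the scatter), that is nothing beyond the scatter. Compound 4 is therefore estimated at 0.085 uM, with a range of 0.04 uM to 0.18 uM.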

Compound 4, concentration for half-maximal effect: 0.079 uM
Beside the measured number, compound 4's estimate is 1.1-fold (0.03 log units) above it; low and high end bracket the measured number.
By their numbers in this assay, from the lowest: compounds 4, 2, 3 and 1 (each within the scatter of the next).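

In this assay, methoxy in place of methyl on this aromatic carbon, para to a large group, gives a 1.1-fold lower number from compound 3 to compound 4 (0.06 log units; within the scatter), so bringing in an oxygen and a hydrogen-bond acceptor leaves the number within the scatter. Methoxy in place of hydrogen gives a 1.6-fold lower number from compound 1 to compound 4 (0.22 log units; within the scatter), which is also within the scatter, so hydrogen, methyl and methoxy at this place cannot be told apart in this assay. Within the data shown here, with methoxy held constant, phenyl in place of 2-phenylethenyl gives a 1.1-fold lower number from compound 2 to compound 4 (0.02 log units; within the scatter), so a second place on the shared core also shows no step beyond the scatter for the one change on record there.

No data are available to explain why these numbers stay so close together. Still open, from the compounds shown here alone, is whether a primary amine, a carboxylic acid or a longer chain such as butoxy on this same aromatic carbon would move the number beyond the scatter, and whether any group at another position on this ring would do so.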